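From Compound 3 to Compound 4: Fluoro Exchanged for Chloro

This account rests on a few compounds, and the source may have more. Where it says the series, first, only, none or still open, it means among the compounds named here.

Compound 1 `Cc1ccccc1CSc1n[nH]c(-n2[se]c3ccccc3c2=O)n1`: 15600 nM
Compound 2 `O=c1c2ccccc2[se]n1-c1nc(SCc2ccc([N+](=O)[O-])cc2)n[nH]1`: 7430 nM
Compound 3 `O=c1c2ccccc2[se]n1-c1nc(SCc2ccc(F)cc2)n[nH]1`: > 50000 nM

In an ADME assay on L929 cells (Mus musculus) for antiproliferative activity, read by CCK-8 assay, with a stated time of 48 h (a lower number here means a stronger inhibitor, a higher number a weaker inhibitor), compound 1 gives 15600 nM and compound 2 gives 7430 nM. For compound 3 the assay reports only a limit, > 50000 nM. Compound 3 thus stands at the weak end of the three, with no number of its own. Compound 4 `O=c1c2ccccc2[se]n1-c1nc(SCc2ccc(Cl)cc2)n[nH]1` differs from it by chloro in place of fluoro on an aromatic carbon. Two measured steps lead into compound 3: an at least 3.2-fold higher number from compound 1 to compound 3 (0.50 log units; beyond the scatter) and an at least 6.7-fold higher number from compound 2 to compound 3 (0.82 log units; beyond the scatter), both ending at the limit of > 50000 nM in this assay, at which 1 of the 3 values shown sits. Going by the values given here, neither involves a chloro group, so they show only that a change at this place can move the number. The step of an at least 1.6-fold lower number from compound 3 to compound 4 (0.22 log units; that floor lies within the scatter) is expected to be small, of uncertain direction. In this assay compound 4 is estimated at 30000 nM, within 7000 nM to 100000 nM.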

Compound 4, half-maximal inhibitory concentration: 39500 nM
Compound 4: the middle estimate sits 1.3-fold (0.12 log units) below what was measured; measured number inside the range.
By their numbers in this assay, from the lowest: compound 2; then compound 1; then compound 4. At a limit, above all of these: compound 3.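

In this assay compound 4 gives a halogen on this aromatic carbon a number of its own, so the distance to the other two substituents can now be sized: a 5.3-fold higher number from compound 2 to compound 4 (0.73 log units; beyond the scatter), and a 2.5-fold higher number from compound 1 to compound 4 (0.40 log units; beyond the scatter). Compound 3 has only a limit, > 50000 nM. That leaves an at least 1.2-fold lower number from compound 3 to compound 4 (0.10 log units; that floor lies within the scatter), a floor within the scatter, so the exchange of fluoro for chloro has no measured size and no firm direction.

On these data alone, whether a bromo, a methoxy or an amine on this aromatic carbon would give a number closer to compound 2 or to compound 4 stays open.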